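A Pyridin-2-yl Exchange in a Flat Cytotoxicity Pair

The source may hold more compounds than are shown below. What is called first, only, known or untested is meant among the compounds shown, and "the series" means these compounds.

In a functional assay on DU-145 cells (Homo sapiens) for cytotoxicity, read by ELISA, with a stated time of 4 days (on this read-out higher numbers stand for weaker inhibition and lower numbers for stronger inhibition), compound 1 (`Clc1ccc(-c2cc(-c3ccoc3)cc(-c3ccco3)n2)s1`) gives 17200 nM and compound 2 (`Clc1ccc(-c2cc(-c3ccoc3)cc(-c3ccccc3Cl)n2)s1`) gives 16400 nM, so compound 2 stands level with compound 1 within the scatter. Compound 3 (`Clc1ccc(-c2cc(-c3ccoc3)cc(-c3ccccn3)n2)s1`) carries pyridin-2-yl in place of 2-chlorophenyl on an aromatic carbon, next to the ring nitrogen of the shared core: pyridin-2-yl in place of 2-chlorophenyl on an aromatic carbon. For the measured compounds named here, only one measured step bears on this exchange. That step, a 1.0-fold lower number from compound 1 to compound 2 (0.02 log units; within the scatter), put 2-chlorophenyl in place of furan-2-yl at the same position and stayed within the scatter. Pyridin-2-yl itself has not been measured here, and a single step is thin evidence, so no shift beyond the scatter is expected in this assay, in either direction. The expected step is a 1.0-fold lower number from compound 2 to compound 3 (0.01 log units; within the scatter). For compound 3 the estimated value is 16000 nM, with an expected range of 7000 nM to 35000 nM.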

Compound 3, half-maximal inhibitory concentration: 20500 nM
Beside the measured number, compound 3's estimate is 1.3-fold (0.11 log units) below it; the measured number falls inside the stated range.
By their numbers in this assay, from the lowest: compounds 2, 1 and 3 (each within the scatter of the next).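

In this assay, the position next to the ring nitrogen now holds three different aromatic rings, and none of them separates from the others. Pyridin-2-yl brings a ring nitrogen and one hydrogen-bond acceptor in place of the chlorine-bearing ring of 2-chlorophenyl (a 1.3-fold higher number from compound 2 to compound 3 (0.10 log units; within the scatter)), and it also stays within the scatter against furan-2-yl (a 1.2-fold higher number from compound 1 to compound 3 (0.08 log units; within the scatter)), so the flat result seen earlier extends to a six-membered ring with a hetero atom. Nothing available here explains why this position shows so little response.

From the compounds shown here alone, all three groups compared here are aromatic rings, so it remains open whether an amine or a carboxylic acid at this position would leave the number equally unmoved. The furan-3-yl and 5-chlorothiophen-2-yl groups stay constant throughout, which leaves their own contribution unknown.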